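The source may report more compounds than this note shows. Statements on the series, on what has been measured and on what is new or still open speak of the compounds shown alone.

Measured compounds:

Compound 3, `Cc1nn(C)c(Oc2ccc(Cl)cc2)c1/C=N\OCc1c(Cl)c(-c2ccc(Cl)cc2)nn1C`, gives 4670 nM in a functional assay on HCT-116 cells (Homo sapiens) for antiproliferative activity, read by MTT assay, with a stated time of 72 h; on this read-out higher numbers stand for weaker inhibition and lower numbers for stronger inhibition.
Compound 1, `Cc1nn(C)c(Oc2ccc(Cl)cc2)c1/C=N\OCc1c(Cl)c(-c2ccc(F)cc2)nn1C`, gives 6030 nM in this assay.
Compound 2, `Cc1nn(C)c(Oc2ccc(F)cc2)c1/C=N\OCc1c(Cl)c(-c2ccc(Cl)cc2)nn1C`, gives 7250 nM in this assay.

Among the measured compounds shown here, compound 3 has the lowest number of the three, but its gaps to the other two are small: the step of a 1.3-fold lower number from compound 1 to compound 3 (0.11 log units; within the scatter) and the step of a 1.6-fold lower number from compound 2 to compound 3 (0.19 log units; within the scatter) both stay within the scatter of repeated measurements, so no compound can be called the stronger one on these data.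

Compound 4, `Cc1nn(C)c(Oc2ccc(Br)cc2)c1/C=N\OCc1c(Cl)c(-c2ccc(Cl)cc2)nn1C`, has not yet been measured. It differs from compound 3 in one place: bromo in place of chloro on an aromatic carbon. The two measured steps bear directly on this question, since each swaps one halogen for another on an aromatic carbon, and neither moved this assay beyond the scatter. A swap of chloro for bromo at the same kind of position is therefore expected to behave alike, with no step beyond the scatter in either direction.

Compound 4 is expected to come out near 4300 nM, within a range of 2000 nM to 9000 nM. The estimated step of a 1.1-fold lower number from compound 3 to compound 4 (0.04 log units; within the scatter) is expected to fall within the usual scatter.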

Compound 4, half-maximal inhibitory concentration: 5910 nM
Compound 4: middle estimate off by 1.4-fold (0.14 log units), on the low side; low and high end bracket the measured number.
By their numbers in this assay, from the lowest: compounds 3, 4, 1 and 2 (each within the scatter of the next).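

Compound 4 brings a third halogen to the same place on the phenoxy ring, para to a large group. In this assay, among the compounds shown here, the step of a 1.3-fold higher number from compound 3 to compound 4 (0.10 log units; within the scatter) and the step of a 1.2-fold lower number from compound 2 to compound 4 (0.09 log units; within the scatter) both stay within the scatter, so fluoro, chloro and bromo at this place cannot be told apart, whereas the earlier compounds covered only fluoro and chloro here. Nothing available explains why this position tolerates these swaps.

Open, on these data alone, is whether a group that is not a halogen at this place, such as an amine, a carboxylic acid or a methoxy group, would give a step beyond the scatter. Also open, as far as these compounds go, is how bromo would read on the other halogen-bearing ring, in place of the chloro of the 4-chlorophenyl group.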